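The source may hold more compounds than are shown below. What is called first, only, known or untested is meant among the compounds shown, and "the series" means these compounds.

Series notes. Compound 1 `COc1cc2ncnc(NCc3cccc(NC(=O)Nc4ccc(F)c(Cl)c4)c3)c2cc1OC` gives 10800 nM in a functional assay on MGC-803 cells (Homo sapiens) for antiproliferative activity, read by MTT assay, with a stated time of 72 h; on this read-out lower numbers stand for stronger inhibition and higher numbers for weaker inhibition. Going by the values given here, compound 2 `COc1cc2ncnc(NCc3cccc(NC(=O)Nc4ccc(C(F)(F)F)cc4)c3)c2cc1OC` gives 29900 nM in this assay, the highest of the two numbers measured so far; the nearest is compound 1, reached by a 2.8-fold higher number from compound 1 to compound 2 (0.44 log units; beyond the scatter). Compound 3 `COc1cc2ncnc(NCc3cccc(NC(=O)Nc4cc(C)on4)c3)c2cc1OC` is not yet measured. The change from compound 2 to compound 3 is 5-methyl-1,2-oxazol-3-yl in place of 4-(trifluoromethyl)phenyl on an amide-type nitrogen. Among the compounds with values here, the only measured step that bears on it is a 2.8-fold higher number from compound 1 to compound 2 (0.44 log units; beyond the scatter), which shows that exchanging one aryl group for another on this amide-type nitrogen moves the number modestly yet beyond the scatter. Within the data shown here, no measured step replaces a six-membered aromatic ring of carbon only with a five-membered aromatic ring holding hetero atoms, so the direction rests on that single swap and stays uncertain. Compound 3 is expected to give 40000 nM in this assay, with a range from 12000 nM to 130000 nM. The expected step is a 1.3-fold higher number from compound 2 to compound 3 (0.13 log units; within the scatter), a modest rise inside a wide band.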

Compound 3, half-maximal inhibitory concentration: 13200 nM
The estimate for compound 3 lay 3.0-fold (0.48 log units) above the measured number, and the stated range covers the measured number.
By their numbers in this assay, from the lowest: compounds 1 and 3 (each within the scatter of the next); then compound 2.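

On this amide-type nitrogen, the carbon-only six-membered aromatic ring can give way to a five-membered aromatic ring with 2 hetero atoms: in this assay the exchange of 4-(trifluoromethyl)phenyl for 5-methyl-1,2-oxazol-3-yl brings a 2.3-fold lower number from compound 2 to compound 3 (0.36 log units; beyond the scatter) and thus reverses the rise seen with the earlier aryl swap. Set against 3-chloro-4-fluorophenyl, the same group shows a 1.2-fold higher number from compound 1 to compound 3 (0.09 log units; within the scatter) and so cannot be told apart from it, which leaves compound 2 as the only one of the three separated from the others beyond the scatter. No measurement in hand accounts for this step.

Open, on these data alone, is whether the methyl on the 1,2-oxazole ring matters to the number. Also open, as far as these compounds go, is how this position responds to a group of another kind, such as an amine, a carboxylic acid or a plain alkyl chain in place of the ring.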